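The source may report more compounds than this note shows. Statements on the series, on what has been measured and on what is new or still open speak of the compounds shown alone.

Compound 1 `Cc1c(OCCCCOc2ccc(C(=O)CC(C)(C)C)c(O)c2C)cccc1C(=O)O` gives 95.8% in an assay on HEK293 cells for positive allosteric modulation of metabotropic glutamate receptor 2 (Rattus norvegicus), read by thallium flux, with a stated time of 2.5 min; on this read-out higher numbers stand for larger maximal responses and lower numbers for smaller maximal responses.
Compound 2 `Cc1c(OCCCCOc2ccc(F)c(C(=O)O)c2)ccc(C(=O)CC(C)(C)C)c1O` gives 94.6% in this assay.

Compound 1 stands level with compound 2 in this assay, since a number 1.2 percentage points lower from compound 1 to compound 2 (within the scatter) is within the scatter. That step alters a group on an oxygen on a saturated carbon and says nothing about the carbonyl side of the molecule. Compound 3 `CCCC(=O)c1ccc(OCCCCOc2cccc(C(=O)O)c2C)c(C)c1O` differs from compound 1 by ethyl in place of tert-butyl on a saturated chain carbon bound to a carbonyl carbon. Going by the values given here, no measured step touches this place, so nothing beyond the scatter is expected in this assay. Compound 3 is estimated at 88% in this assay, from 65% to 105%. The expected step is a number 7.8 percentage points lower from compound 1 to compound 3 (within the scatter).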

Compound 3, largest response reached (reported as percent of maximum), in percent of the reference or control that the assay uses: 82.4%
Beside the measured number, compound 3's estimate is 5.6 percentage points above it, and the stated range covers the measured number.
By their numbers in this assay, from the lowest: compound 3; then compounds 2 and 1 (each within the scatter of the next).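

On the carbonyl side, the series now shows a change that registers in this assay: ethyl in place of tert-butyl on a saturated chain carbon bound to a carbonyl carbon gives a number 13.4 percentage points lower from compound 1 to compound 3 (beyond the scatter). Of the steps shown, this modest one is the only one beyond the scatter. No measurement at hand explains it.

On these data alone, whether the response follows the branching or the length of this chain stays open, as a longer chain, isopropyl or cyclohexyl at this place would have to show. Also open, as far as these compounds go, is whether the same change would give a similar step with the 3-carboxy-4-fluorophenyl group of compound 2.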